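A few compounds are considered here, and "the series" means these few. Any claim that something is new, unique, unknown or untested is made for them only; others in the source may bear on it.

a functional assay on Vero cells (Chlorocebus sabaeus) for inhibition (a lower number here means a stronger inhibitor, a higher number a weaker inhibitor), has so far been applied to three compounds. Compound 1 `Nc1ccn([C@H]2O[C@@H](CO)C=C2F)c(=O)n1` gives > 100000 nM, which is a limit of the assay and not a number. Compound 2 `Nc1nc(O)c2ncn([C@@H]3O[C@@H](CO)C=C3F)c2n1` gives > 100000 nM, again a limit. Going by these compounds, compound 3 `Nc1nc(Cl)c2ncn([C@H]3O[C@@H](CO)C=C3F)c2n1` gives > 100000 nM, also a limit, so its true place on the scale remains unknown. The whole set comes down to the limit of > 100000 nM in this assay, at which 3 of the 3 values shown sit.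

Compound 4 `Nc1nc(O)c2ncn([C@H]3O[C@@H](CO)C=C3F)c2n1` differs from compound 3 in one place: hydroxy in place of chloro on an aromatic carbon. It carries hydroxy in place of chloro on an aromatic carbon, next to the ring nitrogen and meta to an amino group. Among the measured compounds shown here, no measured pair shows what such a swap does in this assay. The expectation is therefore no change beyond the scatter, in either direction, with a reading that most likely stays at the same limit. The estimated step, a number no higher from compound 3 to compound 4 (the limit leaves the size open), is correspondingly small. For compound 4 the estimated value is 100000 nM, with an expected range of 40000 nM to 150000 nM.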

Compound 4, half-maximal inhibitory concentration: > 100000 nM
Compound 4: a limit, no number; the forecaster's own chance of this, stated with the estimate: 85%; the middle value sits exactly at the limit.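

In this assay compound 4 gives > 100000 nM, which is a limit and not a number. The steps to it from compound 3 and compound 2 therefore cannot be read. Left open is whether swapping chloro for hydroxy, or changing the configuration, alters inhibition at all.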